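Series notes on cytotoxicity: from compound 1 to compound 4

The source may report more compounds than this note shows. Statements on the series, on what has been measured and on what is new or still open speak of the compounds shown alone.

Three compounds of the series have so far been run in an ADME assay on PC-3 cells (Homo sapiens) for cytotoxicity, read by WST assay, tested at 100 uM; a lower number here means less inhibition, a higher number more inhibition at the concentration tested (going by the name of the read-out). Compound 1 `O=C(Nc1ccc(Cl)cn1)C1CCCN(C(=O)c2cc(C(F)(F)F)cc(C(F)(F)F)c2)C1` gives 0% in this assay. Compound 2 `O=C(Nc1cccc(Cc2ccccc2)c1)C1CCCN(C(=O)c2cccc(-c3ccco3)c2)C1` gives 0%, and compound 3 `O=C(c1ccccc1)c1cccc(C(=O)N2CCCC(C(=O)Nc3ccc(Cl)cc3)C2)c1` gives 0%. Compound 1 thus stands level with compound 2 and with compound 3 at the digits reported; none of the three is set apart from the others, and the read-out is flat across the measured set. Among the compounds with values here, no pair of measured compounds that differ in a single place is available, so no step size is known from the data.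

Compound 4 `O=C(Nc1cccc(N2CCCC2=O)c1)C1CCCN(C(=O)c2cc(C(F)(F)F)cc(C(F)(F)F)c2)C1` is the next compound to be measured. It differs from compound 1 in one place: 3-(2-oxopyrrolidin-1-yl)phenyl in place of 5-chloropyridin-2-yl on an amide-type nitrogen. The shared core of compound 1 and compound 4 is unchanged.

With the three measured values level, no direction can be read from what has been run, and the expectation is that the change will not move the read-out beyond the scatter; the expected step is no change at the digits printed from compound 1 to compound 4 (within the scatter). Compound 4 is therefore estimated at 0% in this assay, with an expected range from -8% to 12%.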

Compound 4, a percentage reported as inhibition, at one concentration (the size of the read-out at that concentration, not a potency): 0%
Beside the measured number, compound 4's estimate shows no gap at the digits printed; the range from low to high includes it.
By their numbers in this assay, from the lowest: compounds 1, 2, 3 and 4 (each within the scatter of the next).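

Exchanging 5-chloropyridin-2-yl for 3-(2-oxopyrrolidin-1-yl)phenyl on the amide-type nitrogen gives the series its first single-place step in this assay, and that step reads no change at the digits printed from compound 1 to compound 4 (within the scatter). The earlier compounds shown here showed a level read-out only among structures that differ in more than one place, whereas here the shared core is held constant and the read-out still does not separate the two groups, although one has 7 heavy atoms and a chlorine and the other has 12 heavy atoms and an added five-membered non-aromatic ring. No measurement shown here bears on the reason for this result.

All the compounds shown sit at the same level, so they give no sign of whether any group at this position can move the read-out in this assay. As far as these compounds go, whether an aliphatic amine or a carboxylic acid on the group at the amide-type nitrogen would give a value outside the scatter remains open, as does whether the same level would hold with the other end of the shared core altered.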